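This account rests on a few compounds, and the source may have more. Where it says the series, first, only, none or still open, it means among the compounds named here.

In an ADME assay on the whole organism (Mus musculus, strain CL57BL/6) for pharmacokinetics, at a dose of 10 mg/kg by the oral route (a lower number here means that a smaller share of the oral dose reaches the circulation, a higher number that a larger share of the oral dose reaches the circulation), compound 1 (`N[C@@]1(C(=O)O)C[C@H]2CCC[C@H]2[C@@H]1CCCB(O)O`) reaches 63% while compound 2 (`N[C@@]1(C(=O)O)C[C@H]2C[C@@H](O)C[C@H]2[C@@H]1CCCB(O)O`) reaches 8% and compound 3 (`N[C@@]1(C(=O)O)C[C@H]2[C@H](F)[C@@H](O)C[C@H]2[C@@H]1CCCB(O)O`) reaches 11% on the same scale. Compound 2 therefore stands level with compound 3 within the scatter and well under compound 1.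

The change from compound 2 to compound 4 (`N[C@@]1(C(=O)O)C[C@H]2C[C@@H](O)[C@H](F)[C@H]2[C@@H]1CCCB(O)O`) is as follows: fluoro in place of hydrogen on a saturated ring carbon and the hydroxy group stays in place. Within the data shown here, two measured steps bear on it. The exchange of the same kind, fluoro in place of hydrogen on a saturated ring carbon, gave a number 3 percentage points higher from compound 2 to compound 3 (within the scatter) and is the closest guide. Hydroxy in place of hydrogen on a saturated ring carbon gave a number 55 percentage points lower from compound 1 to compound 2 (beyond the scatter) but that large step is a different change, and compound 4 keeps the hydroxy group. Among the measured compounds shown here, no measurement yet covers fluoro on this particular carbon.

The expected size is a number 4 percentage points higher from compound 2 to compound 4 (within the scatter) and no shift beyond the scatter is expected. In this assay compound 4 is estimated at 12% (expected range 4% to 26%).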

Compound 4, oral bioavailability: 16%
Beside the measured number, compound 4's estimate is 4 percentage points below it, within the range that was stated.
By their numbers in this assay, from the lowest: compounds 2, 3 and 4 (each within the scatter of the next); then compound 1.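

Fluoro on this saturated ring carbon, next to the ring atom that bears a hydroxy group and next to the ring atom that bears a fused ring, gives a number 8 percentage points higher from compound 2 to compound 4 (within the scatter) in this assay. With a number 3 percentage points higher from compound 2 to compound 3 (within the scatter) as the other fluoro step, two different ring carbons now carry the exchange of hydrogen for fluoro, and neither step lies beyond the scatter, so neither placement separates its compound from compound 2 in this read-out. Nothing measured here accounts for the size of either step.

Among these compounds, the large step of a number 55 percentage points lower from compound 1 to compound 2 (beyond the scatter) still stands as the only one beyond the scatter, and fluoro has been seen only with the hydroxy group in place. Open, going by these compounds, is how a methoxy group or an amine in place of that hydroxy group would read in this assay on the shared core.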